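This account rests on a few compounds, and the source may have more. Where it says the series, first, only, none or still open, it means among the compounds named here.

In a functional assay on A549 cells (Homo sapiens) for antiproliferative activity, read by MTT assay, with a stated time of 48 h (a lower number here means a stronger inhibitor, a higher number a weaker inhibitor), compound 1 `CC(C)C/C=C1/C(=O)Nc2ccc(Nc3ccc(Cl)cc3)cc21` gives 7400 nM and compound 2 `Cc1ccc(Nc2ccc3c(c2)C(CCC(C)C)C(=O)N3)cc1` gives 6600 nM so these two cannot be told apart, while compound 3 `CC(C)CCC1C(=O)Nc2ccc(Nc3ccc(Cl)cc3)cc21` gives 2000 nM as a lower number than either. Compound 2 therefore stands at the higher end of these numbers, level with compound 1 within the scatter. Compound 4 `Cc1ccc(Nc2ccc3c(c2)C(O)(CCC(C)C)C(=O)N3)cc1` differs from compound 2 by a single change, hydroxy in place of hydrogen on a saturated ring carbon. For the measured compounds named here, the only measured step of this one-place kind, a 3.3-fold lower number from compound 2 to compound 3 (0.52 log units; beyond the scatter) for chloro in place of methyl on an aromatic carbon, is modest but concerns another group on another kind of carbon. Going by the values given here, no measured compound carries this hydroxy, so the data give no firm direction. In this assay a step no larger than that modest one is expected, with a slightly higher number as a cautious guess. The expected change is a 1.2-fold higher number from compound 2 to compound 4 (0.08 log units; within the scatter) as a working estimate. Compound 4 is estimated at 8000 nM with 2500 nM to 25000 nM as the expected range.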

Compound 4, half-maximal inhibitory concentration: 12500 nM
Compound 4: middle estimate off by 1.6-fold (0.19 log units), on the low side; low and high end bracket the measured number.
By their numbers in this assay, from the lowest: compound 3; then compounds 2, 1 and 4 (each within the scatter of the next).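

In this assay, for the compounds shown here, the step of a 1.9-fold higher number from compound 2 to compound 4 (0.28 log units; within the scatter) is the first measured change at this saturated ring carbon, and it lies within the scatter, so compound 4 cannot be told apart from compound 2. Hydroxy in place of hydrogen at this position therefore shows no clear effect on the number, unlike the step of a 3.3-fold lower number from compound 2 to compound 3 (0.52 log units; beyond the scatter), which lies beyond the scatter but concerns an aromatic carbon. Nothing in the data explains this result.

The compounds shown leave open whether a different group on the same ring carbon, such as an amine, a methoxy or a fluoro, would give a step beyond the scatter. They also leave open how hydroxy at this position behaves when the chloro of compound 3 replaces the methyl of compound 4.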